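Compound 3 to compound 4: isopropyl to propyl on sulfur

The source may report more compounds than this note shows. Statements on the series, on what has been measured and on what is new or still open speak of the compounds shown alone.

In an ADME assay on MT4 cells (Homo sapiens) for activation, read by MTT assay (on this read-out higher numbers stand for lower toxicity in this test and lower numbers for higher toxicity in this test), compound 3 `CCc1c(C(C)c2c(F)cccc2F)nc(SC(C)C)[nH]c1=O` gives > 3000 nM, which is a limit of the assay and not a number. Compound 1 `CCCSc1nc(C(C)c2c(F)cccc2Cl)c(CC)c(=O)[nH]1` gives > 3000 nM, also a limit. Compound 2 `CCCSc1nc(C(C)c2c(F)cccc2F)c(C)c(=O)[nH]1` gives > 3000 nM, again a limit. The three measured compounds therefore share one position: the limit of > 3000 nM in this assay, at which 3 of the 3 values shown sit. Compound 3 has no numerical value and cannot be ranked against the other two. Among the compounds with values here, no measured pair differs in one place only, so no measured step is available as a guide.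

Compound 4 `CCCSc1nc(C(C)c2c(F)cccc2F)c(CC)c(=O)[nH]1` has propyl in place of isopropyl on a sulfur, and its atoms are the same as those of compound 3 but joined differently: propyl in place of isopropyl on a sulfur.

No step beyond the usual scatter is expected in this assay, in either direction. This expectation rests on compound 1, which also carries propyl on a sulfur and reads > 3000 nM, a limit. Compound 2 has the same propyl on a sulfur and reads > 3000 nM, also a limit. The expected change is a step that the limit leaves unreadable from compound 3 to compound 4. Compound 4 is estimated at 5000 nM, with an expected range of 3000 nM to 50000 nM.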

Compound 4, half-maximal cytotoxic concentration: > 3000 nM
Compound 4: no number, only a limit; the forecaster's own chance of this, stated with the estimate: 85%; the middle value does not contradict the limit.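

No new step can be read in this assay between compound 4 and compound 1, compound 2 or compound 3, as all four values are limits and not numbers. The series holds one position: the limit of > 3000 nM in this assay, at which 4 of the 4 values shown sit.

The compounds shown leave open how far any of the four lies past that limit, and whether any of these single changes alters the read-out.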